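This account rests on a few compounds, and the source may have more. Where it says the series, first, only, none or still open, it means among the compounds named here.

Measured so far in an ADME assay on microsomes from liver (Homo sapiens) for metabolic stability; on this read-out lower numbers stand for a shorter-lived compound and higher numbers for a longer-lived compound:

- compound 1, `CCCNC(=O)C1CCN(C(=O)c2cc3ncsc3n2Cc2ccc(OC)cc2)CC1`, gives 0.543 h
- compound 2, `CCCNC(=O)C1CCN(C(=O)c2cccn2Cc2ccc(OC)cc2)CC1`, gives 0.112 h
- compound 3, `CCCNC(=O)C1CCN(C(=O)c2ccc(Br)n2Cc2ccc(OC)cc2)CC1`, gives 0.122 h

Compound 2 and compound 3 share one core; compound 1 carries a different core, and the difference between the two cores is not broken down here. The values show compound 1 standing above both compound 2 and compound 3 in this assay, each of those gaps lying beyond the scatter.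

Within the core of compound 2, the single change bromo in place of hydrogen on an aromatic carbon gave a 1.1-fold higher number from compound 2 to compound 3 (0.04 log units; within the scatter), so the bromine left the number essentially where it was.

Compound 4, `CCCNC(=O)C1CCN(C(=O)c2cc3nc(Br)sc3n2Cc2ccc(OC)cc2)CC1`, is not yet measured. It differs from compound 1 by bromo in place of hydrogen on an aromatic carbon. Among the compounds with values here, this is the same kind of change as the one from compound 2 to compound 3, not the same change: in compound 3 the bromo sits on a five-membered aromatic ring with 1 nitrogen, next to the ring atom that bears a 4-methoxybenzyl group, whereas in compound 4 it sits on a five-membered aromatic ring with 1 nitrogen and 1 sulfur, part of a fused system of two rings, next to the ring sulfur.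

Within the data shown here, with only one precedent, the expectation for compound 4 is a step of about a 1.1-fold higher number from compound 1 to compound 4 (0.03 log units; within the scatter), set beside a 1.1-fold higher number from compound 2 to compound 3 (0.04 log units; within the scatter) as the nearest guide, and resting on compound 1 giving 0.543 h as the starting point. Compound 4 is therefore estimated at 0.58 h, with a likely range from 0.3 h to 1.1 h.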

Compound 4, half-life: 0.368 h
Compound 4: the middle estimate sits 1.6-fold (0.20 log units) above what was measured; the range from low to high includes it.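

In this assay, bromo in place of hydrogen on an aromatic carbon of the core of compound 1 gave a 1.5-fold lower number from compound 1 to compound 4 (0.17 log units; within the scatter), so this step, like the earlier one on the core of compound 2, does not go beyond the scatter. Set side by side, the two steps do not differ by more than two such steps can be expected to: the same change on two cores in this assay, a 1.1-fold higher number (0.04 log units; within the scatter) from compound 2 to compound 3 and a 1.5-fold lower number (0.17 log units; within the scatter) from compound 1 to compound 4, 1.6-fold (0.21 log units) apart, within the scatter of two such steps This shows that, across these two pairs, the change carried from one core to the other without a step or a gap beyond the scatter, but it does not show a general rule for the series, since it rests on two pairs with the bromo on different rings, and it gives no explanation for either step.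

The compounds shown leave open whether a group other than bromo on these aromatic carbons, such as methyl, nitrile or an amine, would give a step beyond the scatter on either core. They also leave open how the half-life would respond to changes elsewhere in the series, such as a longer chain in place of the propyl group or a carboxylic acid in place of the methoxy group.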